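Heteroaryl exchange in compound 3: outlook for agonist potency

The compounds below may be only part of what the source reports. "The series", "measured", "known", "first", "only" and "open" are said of these compounds alone.

Compound 2 `CCC(C)(C)Cc1c[nH]c(CCc2ccc(-n3cccn3)cc2)n1` carries a 1H-pyrazol-1-yl group on an aromatic carbon of its pendant six-membered ring. Going by the values given here, in a functional assay on HEK293 cells for agonist activity at Bombesin receptor subtype-3 (Homo sapiens), read by luminescence and calcium flux, with a stated time of 10 min (on this read-out lower numbers stand for an effect already at smaller amounts and higher numbers for an effect only at larger amounts of compound), compound 2 gives 106 nM, the highest of the two numbers obtained so far, though its sole neighbour sits within the scatter of it. That neighbour, compound 1 `CCC(C)(C)Cc1c[nH]c(CCc2ccc(-c3cccnc3)cc2)n1`, gives 98 nM in this assay. Among the compounds with values here, the only step measured to date, a 1.1-fold higher number from compound 1 to compound 2 (0.03 log units; within the scatter), shows that exchanging one small heteroaryl for another at this carbon left the read-out essentially where it was.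

Compound 3 `CCC(C)(C)Cc1c[nH]c(CCc2ccc(-c3ccc(F)cn3)cc2)n1` is unmeasured. It differs from compound 2 by 5-fluoropyridin-2-yl in place of 1H-pyrazol-1-yl on an aromatic carbon. Within the data shown here, the one step that bears on this change is a 1.1-fold higher number from compound 1 to compound 2 (0.03 log units; within the scatter); it was within the scatter, and it involved the same carbon and a heteroaryl of comparable size. On that basis the step of a 1.1-fold lower number from compound 2 to compound 3 (0.03 log units; within the scatter) is expected to stay within the scatter, with no clear direction. For compound 3 the estimate in this assay is 100 nM, with a plausible range from 40 nM to 250 nM.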

Compound 3, half-maximal effective concentration: 97 nM
For compound 3 the middle estimate is 1.0-fold (0.01 log units) above the measured one; measured number inside the range.
By their numbers in this assay, from the lowest: compounds 3, 1 and 2 (each within the scatter of the next).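

At this aromatic carbon, para to a large group, the read-out in this assay now stays put across three heteroaryl groups, with a 1.1-fold lower number from compound 2 to compound 3 (0.04 log units; within the scatter) and a 1.0-fold lower number from compound 1 to compound 3 (0.00 log units; within the scatter) as the two new steps. Going by these compounds alone, the earlier pair covered only one exchange, whereas this one brings in a larger group, with 7 heavy atoms against 5 for 1H-pyrazol-1-yl, a six-membered aromatic ring in place of a five-membered one, and a fluorine, and the step still lies within the scatter. No measurement at hand accounts for this flat read-out.

Going by these compounds, all three groups at this carbon are aromatic rings, so it remains open whether a non-aromatic group there, such as an amine, a carboxylic acid or a morpholine, would leave the read-out in the same place. On these data alone, the share of the fluorine in the result for 5-fluoropyridin-2-yl also remains open, as does the response of the series to any change in the shared core.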